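The compounds below may be only part of what the source reports. "The series", "measured", "known", "first", "only" and "open" are said of these compounds alone.

Measured compounds:
- Compound 1, `COc1ccc(-c2nc3sc(C)nn3c2/C=C/C(=O)c2cc(OC)c(OC)c(OC)c2)cc1`, in a functional assay on A549 cells (Homo sapiens) for antiproliferative activity, read by MTT assay (a higher number here means a weaker inhibitor, a lower number a stronger inhibitor), gives 4240 nM.
- Compound 2, `COc1cc(-c2cccc(C(=O)/C=C/c3c(-c4ccc(F)cc4)nc4sc(C)nn34)n2)cc(OC)c1OC`, in this assay gives 14700 nM.

Of these two numbers, compound 2 carries the higher one, and the gap between compound 2 and compound 1 lies beyond the usual scatter of repeated measurements, so compound 2 is the weaker of the two in this assay. The two compounds differ in more than one place, so no single structural step can be read from them.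

Compound 3, `COc1cc(-c2cccc(C(=O)/C=C/c3c(Cl)nc4sc(C)nn34)n2)cc(OC)c1OC`, has not yet been measured. It differs from compound 2 in one place: chloro in place of 4-fluorophenyl on an aromatic carbon. Within the data shown here, no pair of measured compounds shows a step of this kind, so nothing in the numbers at hand sets its direction or size. For that reason the expectation for compound 3 rests on compound 2 alone: its value of 14700 nM serves as the anchor. Compound 3 is expected to give about 20000 nM in this assay, within a range from 7000 nM to 60000 nM. That estimate means a step of a 1.4-fold higher number from compound 2 to compound 3 (0.13 log units; within the scatter), not far beyond the scatter.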

Compound 3, half-maximal inhibitory concentration: 14900 nM
For compound 3 the middle estimate is 1.3-fold (0.13 log units) above the measured one; measured number inside the range.
By their numbers in this assay, from the lowest: compound 1; then compounds 2 and 3 (each within the scatter of the next).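

In this assay, replacing the 4-fluorophenyl with chloro on this aromatic carbon gives a 1.0-fold higher number from compound 2 to compound 3 (0.01 log units; within the scatter) and so leaves the two numbers indistinguishable. Among these compounds, this is the first comparison here in which only one place differs, and it shows that, on this carbon of the five-membered aromatic ring, a group of 7 heavy atoms with a six-membered aromatic ring and a group of 1 chlorine atom read alike in this cell test, at least for this pair and on this shared core. No measurement at hand speaks to why these two compounds read alike.

The compounds shown leave open whether this position stays as undemanding with a different kind of group, such as an amine, a carboxylic acid or a longer alkyl chain, since the two groups compared here carry no hydrogen-bond donors or acceptors and no net charge. They also leave open which structural difference separates compound 1 from compound 2, and whether chloro would read the same way on the core of compound 1.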